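Carboxylic acid for fluorine on the pyridine of compound 2

This account rests on a few compounds, and the source may have more. Where it says the series, first, only, none or still open, it means among the compounds named here.

Compound 2 `Fc1ccnc(Nc2cc3[nH]c(-c4ccc(F)c(F)c4)nc3cn2)c1` gives 166000 nM in a physicochemical assay for solubility, using the shake flask method, measured as kinetic solubility, with a stated time of 20 h, at pH 2 (on this read-out lower numbers stand for lower solubility and higher numbers for higher solubility), the higher of the two numbers in hand, with compound 1 `Fc1ccc(-c2nc3cnc(Nc4ccccn4)cc3[nH]2)cc1F` nearest at 125000 nM. Going by the values given here, the only measured step, a 1.3-fold higher number from compound 1 to compound 2 (0.12 log units; within the scatter), concerns a fluoro in place of hydrogen and lies within the scatter. Compound 3 `O=C(O)c1ccc(Nc2cc3[nH]c(-c4ccc(F)c(F)c4)nc3cn2)nc1` differs from compound 2 by 5-carboxypyridin-2-yl in place of 4-fluoropyridin-2-yl on a nitrogen on an aromatic ring. Among the compounds with values here, no measured step covers an exchange of this kind, since the one step in hand changes a single fluoro only, so there is no precedent on which to build a direction. With nothing pointing either way, compound 3 is expected to land close to compound 2 in this assay, and the step of a 1.4-fold lower number from compound 2 to compound 3 (0.14 log units; within the scatter) is estimated as no more than the scatter allows. The estimate for compound 3 in this assay is 120000 nM, with a range from 20000 nM to 500000 nM.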

Compound 3, solubility: 11000 nM
Estimate against measurement, compound 3: 11-fold (1.04 log units) above; measured number outside the range, below it.
By their numbers in this assay, from the lowest: compound 3; then compounds 1 and 2 (each within the scatter of the next).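

In this assay, the group on the nitrogen on an aromatic ring now proves able to move the read-out: 5-carboxypyridin-2-yl in place of 4-fluoropyridin-2-yl gives a 15-fold lower number from compound 2 to compound 3 (1.18 log units; beyond the scatter) and so goes well beyond the fluoro exchange, which gave only a 1.3-fold higher number from compound 1 to compound 2 (0.12 log units; within the scatter) in the earlier pair. The carboxylic acid gives an 11-fold lower number from compound 1 to compound 3 (1.06 log units; beyond the scatter) as well, so the drop appears whether the comparison starts from the fluoro compound or from the compound without fluoro. No measurement in hand accounts for this drop.

From the compounds shown here alone, whether a methyl ester, a primary amide or an aminomethyl group on the same pyridine would give a step of this size stays open. So does whether the carboxylic acid would act alike at another place on that ring.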